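The source may report more compounds than this note shows. Statements on the series, on what has been measured and on what is new or still open speak of the compounds shown alone.

In a functional assay on CHO-TAX 5-6 cells (Cricetulus griseus) for antiproliferative activity, read by sulforhodamine B assay, with a stated time of 48 h (on this read-out lower numbers stand for stronger inhibition and higher numbers for weaker inhibition), the measured compounds read:
compound 1 `O=C1NCCN1c1ccc(S(=O)(=O)Nc2ccc3[nH]ccc3c2)cc1` gives 640 nM
compound 2 `Cc1cccc(NS(=O)(=O)c2ccc(N3CCNC3=O)cc2)c1` gives 150 nM
compound 3 `Cc1cc(C)cc(NS(=O)(=O)c2ccc(N3CCNC3=O)cc2)c1` gives 120 nM

Compound 3 cannot be told apart from compound 2 on these numbers, and both stand clearly under compound 1. Compound 4 `COc1cccc(NS(=O)(=O)c2ccc(N3CCNC3=O)cc2)c1` has not yet been measured. It carries 3-methoxyphenyl in place of 3,5-dimethylphenyl on a sulfonamide nitrogen. Among the measured compounds shown here, the one measured step that bears on this is methyl in place of hydrogen on an aromatic carbon (a 1.3-fold lower number from compound 2 to compound 3 (0.10 log units; within the scatter)), which is small and within the scatter. For the measured compounds named here, no measured step covers a 3-methoxyphenyl group, so no shift beyond the scatter is expected in this assay in either direction. The estimated change (a 1.4-fold higher number from compound 3 to compound 4 (0.15 log units; within the scatter)) is expected to stay within the scatter. For compound 4 the estimate is 170 nM (expected range 70 nM to 400 nM).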

Compound 4, half-maximal inhibitory concentration: 200 nM
Compound 4: the middle estimate sits 1.2-fold (0.07 log units) below what was measured; low and high end bracket the measured number.
By their numbers in this assay, from the lowest: compounds 3, 2 and 4 (each within the scatter of the next); then compound 1.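

In this assay the step to 3-methoxyphenyl on a sulfonamide nitrogen is a 1.7-fold higher number from compound 3 to compound 4 (0.22 log units; within the scatter) and the step to methoxy in place of methyl on an aromatic carbon is a 1.3-fold higher number from compound 2 to compound 4 (0.12 log units; within the scatter). Compound 2 and compound 3 carry only methyl on this aromatic ring, so compound 4 adds the first oxygen and hydrogen-bond acceptor there, with no shift beyond the scatter. No evidence is available to explain this result. The compounds shown leave open whether an amine or a carboxylic acid in place of the methoxy would also stay within the scatter.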